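Methyl for fluorine on a cyclopropyl amide

The compounds below may be only part of what the source reports. "The series", "measured", "known", "first", "only" and "open" are said of these compounds alone.

Compound 3 `O=C([C@@H]1C[C@H]1F)N1CC2CC(C1)N2` gives the lowest number among the three compounds measured in an assay on CHO cells for agonist activity at Neuronal acetylcholine receptor; alpha3/alpha6/beta2/beta3 (Homo sapiens), read by FLIPR and calcium flux (on this read-out lower numbers stand for an effect already at smaller amounts and higher numbers for an effect only at larger amounts of compound), at 53 nM. Compound 1 `CCC(=O)N1CC2CC(C1)N2` gives 180 nM in this assay, and compound 2 `CCCC(=O)N1CC2CC(C1)N2` gives 300 nM. The two steps that lead to compound 3 both lowered the number: a 3.4-fold lower number from compound 1 to compound 3 (0.53 log units; beyond the scatter) and a 5.7-fold lower number from compound 2 to compound 3 (0.75 log units; beyond the scatter). The step between the two open-chain amides, a 1.7-fold higher number from compound 1 to compound 2 (0.22 log units; within the scatter), stayed within the scatter.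

Compound 4 `C[C@@H]1C[C@@H]1C(=O)N1CC2CC(C1)N2` has not yet been measured. It differs from compound 3 in one place: a group of 4 heavy atoms (4 carbon; one three-membered non-aromatic ring of carbon only) in place of a group of 4 heavy atoms (3 carbon, 1 fluorine; one three-membered non-aromatic ring of carbon only), on a carbonyl carbon. Among the measured compounds shown here, no measured step bears directly on exchanging a fluorine for a carbon on the three-membered ring; the steps that do exist, a 3.4-fold lower number from compound 1 to compound 3 (0.53 log units; beyond the scatter) and a 5.7-fold lower number from compound 2 to compound 3 (0.75 log units; beyond the scatter), compare the 2-fluorocyclopropyl group with the ethyl and propyl chains and show that the ring amide gave the lowest number of the three. Since compound 4 keeps the three-membered ring on the carbonyl carbon, the expected step is a 1.7-fold higher number from compound 3 to compound 4 (0.23 log units; within the scatter), which stays within the scatter. Compound 4 is therefore estimated at 90 nM, with a range from 35 nM to 250 nM.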

Compound 4, half-maximal effective concentration: 920 nM
Compound 4: the middle estimate sits 10-fold (1.01 log units) below what was measured; the whole stated range lies below it.
By their numbers in this assay, from the lowest: compound 3; then compounds 1 and 2 (each within the scatter of the next); then compound 4.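

In this assay the three-membered ring on the carbonyl carbon does not by itself bring the low number, since the 2-fluorocyclopropyl group gives way to an all-carbon group with the same ring and the number rises sharply (a 17-fold higher number from compound 3 to compound 4 (1.24 log units; beyond the scatter)). The all-carbon ring group also stands above both open-chain amides (a 3.1-fold higher number from compound 2 to compound 4 (0.49 log units; beyond the scatter); a 5.1-fold higher number from compound 1 to compound 4 (0.71 log units; beyond the scatter)), so replacing an open chain with a ring on this carbonyl carbon lowers the number only in the fluorinated compound 3 and raises it in compound 4, and among these four compounds the lowest number goes with the fluorine-bearing ring rather than with the ring as such. Among the compounds shown here, nothing available explains why this exchange on the ring shifts the number so far.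

The compounds shown leave open where the plain cyclopropyl group, or a ring carrying chlorine, a hydroxyl group or trifluoromethyl, would fall relative to compound 3 and compound 4. They also leave open how the number depends on the arrangement at the two defined stereocentres, as each ring group appears here in a single form.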